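Chloro Entering the 4-Fluorophenyl Group: Compound 4

A few compounds are considered here, and "the series" means these few. Any claim that something is new, unique, unknown or untested is made for them only; others in the source may bear on it.

Three compounds of the series have numbers in a functional assay on A-431 cells (Homo sapiens) for antiproliferative activity, read by CCK-8 assay, with a stated time of 48 h; a higher number here means a weaker inhibitor, a lower number a stronger inhibitor. Compound 1 `Cc1cc(Nc2cc(N3CCN(C)CC3)nc(Nc3ccc(F)c(F)c3)n2)n[nH]1` gives 177 nM. Compound 2 `Cc1cc(Nc2cc(N3CCN(C)CC3)nc(Nc3ccc(F)cc3)n2)n[nH]1` gives 340 nM, the second highest of the three numbers; its nearest neighbour is compound 1, with a 1.9-fold higher number from compound 1 to compound 2 (0.28 log units; within the scatter), and its furthest is compound 3 `COc1ccc(Nc2nc(Nc3cc(C)[nH]n3)cc(N3CCN(C)CC3)n2)cc1OC`, which gives 778 nM. Among the compounds with values here, the steps of a 4.4-fold higher number from compound 1 to compound 3 (0.64 log units; beyond the scatter) and a 2.3-fold higher number from compound 2 to compound 3 (0.36 log units; beyond the scatter) both belong to the exchange of a fluorinated phenyl for the 3,4-dimethoxyphenyl group and are the only steps beyond the scatter.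

Compound 4 `Cc1cc(Nc2cc(N3CCN(C)CC3)nc(Nc3ccc(F)c(Cl)c3)n2)n[nH]1` differs from compound 2 by chloro in place of hydrogen on an aromatic carbon, so that the (4-fluorophenyl)amino group becomes (3-chloro-4-fluorophenyl)amino. The step that bears on it most directly is a 1.9-fold higher number from compound 1 to compound 2 (0.28 log units; within the scatter), where a halogen at the same aromatic carbon was replaced by hydrogen and the number moved only within the scatter. The dimethoxy steps do not bear on a single halogen. A halogen re-entering that position is therefore expected to give at most a small step towards a lower number in this assay, possibly none beyond the scatter.

Compound 4 is expected to give 200 nM, within 90 nM to 450 nM, which means an expected step of a 1.7-fold lower number from compound 2 to compound 4 (0.23 log units; within the scatter).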

Compound 4, half-maximal inhibitory concentration: 80.9 nM
Compound 4: middle estimate off by 2.5-fold (0.39 log units), on the high side; the whole stated range lies above it.
By their numbers in this assay, from the lowest: compound 4; then compounds 1 and 2 (each within the scatter of the next); then compound 3.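

In this assay, the aromatic carbon ortho to the fluoro group proves responsive to what it carries: chloro in place of hydrogen gives a 4.2-fold lower number from compound 2 to compound 4 (0.62 log units; beyond the scatter), whereas fluoro and hydrogen on that carbon did not separate beyond the scatter. The two halogens are not interchangeable at this carbon, as chloro in place of fluoro gives a 2.2-fold lower number from compound 1 to compound 4 (0.34 log units; beyond the scatter), and the exchange of the 3,4-dimethoxyphenyl group for 3-chloro-4-fluorophenyl gives a 9.6-fold lower number from compound 3 to compound 4 (0.98 log units; beyond the scatter), leaving compound 4 with the lowest number of the four, beyond the scatter from each of the others. Nothing available explains the difference between chloro and fluoro at this carbon.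

The compounds shown leave open whether bromo, methyl or trifluoromethyl on the same carbon would continue the step seen with chloro or reverse it. They also leave open whether chloro gives a comparable step without the 4-fluoro group, as in a 3-chlorophenyl analogue, and whether the step persists when the 4-methylpiperazine or the methylpyrazole part of the core is exchanged for another amine or another ring.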